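Replacing the Aryl Group of Compound 1

A few compounds are considered here, and "the series" means these few. Any claim that something is new, unique, unknown or untested is made for them only; others in the source may bear on it.

In a functional assay on MCF7 cells (Homo sapiens) for antiproliferative activity, read by MTT assay, with a stated time of 72 h (on this read-out higher numbers stand for weaker inhibition and lower numbers for stronger inhibition), compound 1 (`CCNC(=O)c1cc(Oc2ccc(NC(=O)c3nn(-c4ccc(Br)cc4F)c(=O)cc3C)cc2)ccn1`) gives 35100 nM and compound 2 (`CCCNC(=O)c1cc(Oc2ccc(NC(=O)c3nn(-c4ccc(C)cc4)c(=O)cc3C)cc2F)ccn1`) gives 34600 nM so the two stand level within the scatter, and neither can be placed ahead of the other. Compound 3 (`CCNC(=O)c1cc(Oc2ccc(NC(=O)c3nn(-c4cccc(F)c4)c(=O)cc3C)cc2)ccn1`) carries 3-fluorophenyl in place of 4-bromo-2-fluorophenyl on an aromatic nitrogen. For the measured compounds named here, no two measured compounds differ in one place only, so nothing measured sizes this change. The expected step (a 1.4-fold lower number from compound 1 to compound 3 (0.15 log units; within the scatter)) in this assay leans slightly toward a lower number and stays within the scatter. For compound 3 the estimated value is 25000 nM (range 9000 nM to 60000 nM).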

Compound 3, half-maximal inhibitory concentration: 18900 nM
Beside the measured number, compound 3's estimate is 1.3-fold (0.12 log units) above it; the range from low to high includes it.
By their numbers in this assay, from the lowest: compounds 3, 2 and 1 (each within the scatter of the next).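

In this assay this aromatic nitrogen now has its first one-place comparison, which gives a 1.9-fold lower number from compound 1 to compound 3 (0.27 log units; within the scatter) and sizes the exchange of 4-bromo-2-fluorophenyl for 3-fluorophenyl directly. The two aryl groups therefore cannot be told apart on this read-out. Nothing available accounts for the size of this step.

This single step does not separate the loss of the bromine from the different place of the fluorine. Going by these compounds, how an amine, a carboxylic acid or a methoxy group on this phenyl ring would read out remains open.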